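The source may report more compounds than this note shows. Statements on the series, on what has been measured and on what is new or still open speak of the compounds shown alone.

Compound 1 `COc1cc(/C=C/C(=O)c2cccc(-n3cc(-c4ccc(Cl)cc4)[nH]c3=O)c2)cc(OC)c1OC`: 13800 nM
Compound 2 `COc1cc(/C=C/C(=O)c2cccc(-n3cc(-c4ccccc4)[nH]c3=O)c2)ccc1O`: 3360 nM

In a functional assay on MDA-MB-231 cells (Homo sapiens) for inhibition (on this read-out higher numbers stand for weaker inhibition of growth and lower numbers for stronger inhibition of growth), compound 1 has the higher number of the two, which means weaker growth inhibition, and the gap to compound 2 lies beyond the scatter. Compound 3 `COc1cc(/C=C/C(=O)c2cccc(-n3cc(-c4cc(OC)c(OC)c(OC)c4)[nH]c3=O)c2)cc(OC)c1OC` keeps the core of compound 1 but carries 3,4,5-trimethoxyphenyl in place of 4-chlorophenyl on an aromatic carbon. Within the data shown here, no measured pair shows this change alone. Differing from compound 1 in more than one place, the only guide is compound 2, which reads 3360 nM. A modest fall in this assay is therefore expected, with the expected step being a 2.3-fold lower number from compound 1 to compound 3 (0.36 log units; beyond the scatter). For compound 3, the estimated value is 6000 nM, within an expected range of 1800 nM to 20000 nM.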

Compound 3, concentration for 50% growth inhibition: 4190 nM
Compound 3: middle estimate off by 1.4-fold (0.16 log units), on the high side, and the stated range covers the measured number.
By their numbers in this assay, from the lowest: compounds 2 and 3 (each within the scatter of the next); then compound 1.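

In this assay, replacing 4-chlorophenyl with the larger 3,4,5-trimethoxyphenyl on this aromatic carbon gives modestly stronger growth inhibition (a 3.3-fold lower number from compound 1 to compound 3 (0.52 log units; beyond the scatter)). Among these compounds, this is the first comparison that isolates a change at this position, and it shows that the bigger group is accepted here without any loss of growth inhibition. Nothing available explains the gain. As far as these compounds go, it remains open whether the gain comes from adding the methoxy groups or from losing the chlorine. From the compounds shown here alone, how an amine or a carboxylic acid on this phenyl ring would read also remains open.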